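Chloro in place of hydrogen: two matched pairs compared

A few compounds are considered here, and "the series" means these few. Any claim that something is new, unique, unknown or untested is made for them only; others in the source may bear on it.

Compound 1 `O=C(Nc1ccc(-c2noc(-c3cccc(NS(=O)(=O)c4ccccc4)c3)n2)c(Cl)c1)c1cccnc1` and compound 2 `O=C(Nc1ccc(-c2noc(-c3cccc(NS(=O)(=O)c4cccc(Cl)c4)c3)n2)c(Cl)c1)c1cccnc1` share one core and differ in a single change, (chloro in place of hydrogen on an aromatic carbon). In a functional assay on MDA-MB-231 cells (Homo sapiens) for antiproliferative activity, read by MTT assay, with a stated time of 72 h (a lower number here means a stronger inhibitor, a higher number a weaker inhibitor), compound 1 gives > 10000 nM, which is a limit of the assay and not a number. Compound 2 gives > 10000 nM in this assay, again a limit. Among the measured compounds shown here, the step that the two limits leave unreadable from compound 1 to compound 2 cannot be sized; the only evidence that bears on it is the limit of > 10000 nM in this assay, at which 2 of the 3 values shown sit.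

Compound 3 `CC(=O)Nc1ccc(S(=O)(=O)Nc2cccc(-c3nc(-c4ccc(NC(=O)c5cccnc5)cc4)no3)c2)cc1` has a different core; the difference between the two cores is not broken down here. In this assay, for the measured compounds named here, compound 3 gives 5200 nM, the one number among the three values shown. Compound 4 `CC(=O)Nc1ccc(S(=O)(=O)Nc2cccc(-c3nc(-c4ccc(NC(=O)c5cccnc5)c(Cl)c4)no3)c2)cc1` is not yet measured and differs from compound 3 by chloro in place of hydrogen on an aromatic carbon. This is the same kind of change as that from compound 1 to compound 2, not the same: in compound 3 the place is ortho to a ((pyridin-3-yl)carbonyl)amino group (9 heavy atoms) as well as meta to a large group, whereas in compound 1 the place is described only as meta to a large group.

The measured pair gives no readable size for this change, so the expectation for compound 4 rests on compound 3 alone. The step of a 1.0-fold lower number from compound 3 to compound 4 (0.02 log units; within the scatter) is expected to be small. Compound 4 is therefore estimated to give about 5000 nM in this assay, within a range of 1500 nM to 15000 nM, with a fair chance that only a limit is returned.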

Compound 4, half-maximal inhibitory concentration: 4500 nM
The estimate for compound 4 lay 1.1-fold (0.05 log units) above the measured number; the range from low to high includes it.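

In this assay, chloro in place of hydrogen on an aromatic carbon, ortho to a ((pyridin-3-yl)carbonyl)amino group and meta to a large group, gives a 1.2-fold lower number from compound 3 to compound 4 (0.06 log units; within the scatter), so in the core of compound 3 this change leaves no difference that can be told from the scatter. Among the compounds shown here, the matching step in the core of compound 1 cannot be read, and the only evidence that bears on it is this: the limit of > 10000 nM in this assay, at which 2 of the 4 values shown sit. For the compounds shown here, the change has therefore been sized in one core only, which neither confirms nor contradicts its transfer between cores, and the single readable pair shows nothing about the same change in the core of compound 1 or at any other place on the ring.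

The compounds shown leave open whether a different group at this place, such as an amine, a methoxy group or a carboxylic acid, would give a step beyond the scatter in the core of compound 3. Also open, going by these compounds, is whether a longer chain at this place would give a readable number in this assay in the core of compound 1.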